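A few compounds are considered here, and "the series" means these few. Any claim that something is new, unique, unknown or untested is made for them only; others in the source may bear on it.

Of the compounds shown here, three sharing one core have so far been measured in a functional assay on microsomes for inhibition, with a stated time of 1 h; on this read-out lower numbers stand for stronger inhibition and higher numbers for weaker inhibition. Compound 1 `CCOC(=O)c1cnn(-c2nc(-c3ccc(OC)cc3)c(C#N)c(=O)n2C)c1N` gives 68 ug/mL. Compound 2 `CSc1nc(-c2ccccc2Cl)c(C#N)c(=O)n1C` gives 72 ug/mL in this assay, and compound 3 `Cn1c(NN)nc(-c2ccccc2F)c(C#N)c1=O` gives 43 ug/mL. On these numbers compound 1 holds the second highest value of the three, yet its gap to compound 2 and its gap to compound 3 both lie within the usual scatter of repeated measurements, so none of the three can be set apart from the others. Going by the values given here, no pair among them differs in a single place, so no measured step guides the change now considered.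

Compound 4 `CCOC(=O)c1cnn(-c2nc(-c3ccc(Cl)cc3)c(C#N)c(=O)n2C)c1N` has not yet been measured. It differs from compound 1 in one place: chloro in place of methoxy on an aromatic carbon. Among the compounds with values here, nothing among the measured compounds shows what this exchange does in this assay. The step of a 1.1-fold lower number from compound 1 to compound 4 (0.05 log units; within the scatter) is therefore expected to be small, with no direction that reaches beyond the scatter. Compound 4 is estimated to give 60 ug/mL in this assay, with a range from 30 ug/mL to 120 ug/mL.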

Compound 4, half-maximal inhibitory concentration: 88 ug/mL
Beside the measured number, compound 4's estimate is 1.5-fold (0.17 log units) below it; the measured number falls inside the stated range.
By their numbers in this assay, from the lowest: compounds 3, 1, 2 and 4 (each within the scatter of the next, the first and the last beyond it).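

In this assay, going by these compounds alone, chloro in place of methoxy on an aromatic carbon gives a 1.3-fold higher number from compound 1 to compound 4 (0.11 log units; within the scatter), the first measured step at this position. Compound 1 and compound 4 therefore cannot be told apart, and this position, para to a large group, tolerates the exchange of 4-methoxyphenyl for 4-chlorophenyl with no shift that exceeds the scatter. No measurement at hand bears on what lies behind this step.

The compounds shown leave open whether an amine, a carboxylic acid or a longer chain such as butoxy at this position would give a step beyond the scatter. They also leave open whether chloro in place of methoxy would read the same with the groups of compound 2 or compound 3 on the shared core.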